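The source may hold more compounds than are shown below. What is called first, only, known or untested is meant among the compounds shown, and "the series" means these compounds.

Measured compounds in a physicochemical assay for lipophilicity, using the shake flask method; on this read-out higher numbers stand for higher lipophilicity and lower numbers for lower lipophilicity:
compound 1 `Nc1ncnc(Oc2ccc(NC(=O)C3(C(=O)Nc4ccc(F)cc4)CC3)cc2F)c1/C=N/OCCO`: 2.37
compound 2 `CCOC(=O)CO/N=C/c1c(N)ncnc1Oc1ccc(NC(=O)C2(C(=O)Nc3ccc(F)cc3)CC2)cc1F`: 3.15

Compound 2 stands highest of the two numbers; the step of a number 0.78 log units higher from compound 1 to compound 2 (beyond the scatter) lies beyond the scatter. Compound 3 `Nc1ncnc(Oc2ccc(NC(=O)C3(C(=O)Nc4ccc(F)cc4)CC3)cc2F)c1/C=N/OCc1ccccc1` is not yet measured. It differs from compound 2 in one place: phenyl in place of ethoxycarbonyl on a saturated chain carbon bound to an oxygen on an unsaturated carbon. Among the measured compounds shown here, no measured step covers this exact exchange; the only known step, a number 0.78 log units higher from compound 1 to compound 2 (beyond the scatter), shows that an exchange at this same chain carbon moves this assay modestly. A further rise is expected, a number 1.15 log units higher from compound 2 to compound 3 (beyond the scatter). Compound 3 is therefore estimated at 4.3, with a range of 3.6 to 5.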

Compound 3, partition coefficient: 4.45
The estimate for compound 3 lay 0.15 log units below the measured number; measured number inside the range.
By their numbers in this assay, from the lowest: compound 1; then compound 2; then compound 3.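

Phenyl on this saturated chain carbon gives a number 1.30 log units higher from compound 2 to compound 3 (beyond the scatter) in this assay and, against hydroxymethyl, a number 2.08 log units higher from compound 1 to compound 3 (beyond the scatter) in the same read-out. Both steps are large, while a number 0.78 log units higher from compound 1 to compound 2 (beyond the scatter) was modest, so the exchanges at this carbon reach further than the first pair showed, with hydroxymethyl, ethoxycarbonyl and phenyl in rising order. No supporting measurement on hand accounts for the size of these steps. Still open, as far as these compounds go, is how an amine or a carboxylic acid on this carbon would read in this assay and whether a longer chain carrying the phenyl would shift the number further.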